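Azido analogue of a deoxy sugar: stereocentre inversion at the ring

The source may hold more compounds than are shown below. What is called first, only, known or untested is meant among the compounds shown, and "the series" means these compounds.

Measured so far:
compound 1, `C[C@H]1O[C@H](CO)[C@@H](O)[C@H](O)[C@H]1O`, 50100000 nM
compound 2, `[N-]=[N+]=NC[C@H]1O[C@H](CO)[C@@H](O)[C@H](O)[C@H]1O`, 25100000 nM

Two compounds have been run in an assay on isolated protein (Sus scrofa) for inhibition of glycogen phosphorylase, brain form (Homo sapiens); on this read-out higher numbers stand for weaker inhibition and lower numbers for stronger inhibition. Compound 1 is the parent deoxy sugar; compound 2 carries an azido group in place of a hydrogen on the saturated chain carbon bound to a saturated ring carbon, and the step of a 2.0-fold lower number from compound 1 to compound 2 (0.30 log units; within the scatter). Within the data shown here, compound 2 therefore stands at the lower of the two numbers seen, with compound 1 its only neighbour and the gap between them within the scatter, so no order between the two can be claimed.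

The next compound, compound 3, `[N-]=[N+]=NC[C@@H]1O[C@H](CO)[C@@H](O)[C@H](O)[C@H]1O`, keeps all atoms and bonds of compound 2 and differs only in configuration: the two compounds have the same atoms and bonds; at least one stereo element is drawn with a configuration in one of them and without one in the other: 1 of 6 stereo elements differ; a stereocentre at a saturated ring carbon is drawn R in compound 2 and S in compound 3. Among the measured compounds shown here, no measured step bears on a change of configuration; the single measured step, from compound 1 to compound 2, concerns a substituent and is within the scatter. Nothing measured therefore points to a direction, and the expectation rests on compound 2 alone. The estimated step of a 1.0-fold lower number from compound 2 to compound 3 (0.00 log units; within the scatter) is no change beyond the scatter, with a wide range to allow for either direction. For compound 3 the expected value in this assay is 25000000 nM, estimated between 5000000 nM and 125000000 nM.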

Compound 3, inhibition constant: 15800000 nM
Compound 3: middle estimate off by 1.6-fold (0.20 log units), on the high side, and the stated range covers the measured number.
By their numbers in this assay, from the lowest: compounds 3, 2 and 1 (each within the scatter of the next, the first and the last beyond it).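

In this assay, the change of configuration at the saturated ring carbon, drawn R in compound 2 and S in compound 3, gives a 1.6-fold lower number from compound 2 to compound 3 (0.20 log units; within the scatter), so this stereocentre now has a measured step of its own and neither drawing can be preferred over the other. The earlier step concerned only the azido group in place of hydrogen, and it said nothing about configuration; with this result, the substituent change and the configurational change have each been read once, and both lie within the scatter. The reading of this step as a comparison of two defined configurations carries one reservation, and the step cannot be taken as a clean inversion at this stereocentre: the fact that one of compounds 2 and 3 is drawn with a defined configuration and the other without, at the place where they differ

The compounds shown leave open whether an amine or a carboxylic acid in place of the azido group, or a longer chain carrying it, would give a step beyond the scatter. They also leave open whether the configuration at this saturated ring carbon would count for more with one of those groups in place.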